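From Methyl to Trifluoromethyl on an Aromatic Carbon

A few compounds are considered here, and "the series" means these few. Any claim that something is new, unique, unknown or untested is made for them only; others in the source may bear on it.

Compound 1 `CCOc1ccc(N/N=C2\CCC(C)n3c2ncc(C(=O)O)c3=O)cc1`: 17600 nM
Compound 2 `Cc1ccc(N/N=C2\CCC(C)n3c2ncc(C(=O)O)c3=O)cc1`: 280 nM

In a functional assay (mast cells) for inhibition, with Rattus norvegicus as the target (a higher number here means that more compound is needed for the effect, a lower number that less compound is needed), compound 2 holds the lower of the two numbers, at 280 nM. Compound 3 `CC1CC/C(=N\Nc2ccc(C(F)(F)F)cc2)c2ncc(C(=O)O)c(=O)n21` has trifluoromethyl in place of methyl on an aromatic carbon. For the measured compounds named here, only one measured step bears on this change: a 63-fold lower number from compound 1 to compound 2 (1.80 log units; beyond the scatter), a large step with methyl in place of ethoxy. It shows that the group on this carbon can matter, but it does not test trifluoromethyl. A smaller step towards a higher number is therefore expected. The expected step is a 2.1-fold higher number from compound 2 to compound 3 (0.33 log units; beyond the scatter). The estimate for compound 3 is 600 nM, with an expected range of 120 nM to 3500 nM.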

Compound 3, half-maximal effective concentration: 280 nM
Compound 3: middle estimate off by 2.1-fold (0.33 log units), on the high side; the range from low to high includes it.
By their numbers in this assay, from the lowest: compounds 2 and 3 (each within the scatter of the next); then compound 1.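

In this assay, trifluoromethyl in place of methyl on this aromatic carbon gives no change at the digits printed from compound 2 to compound 3 (within the scatter), so here the position accepts the change from one heavy atom to four. Trifluoromethyl in place of ethoxy gives a 63-fold lower number from compound 1 to compound 3 (1.80 log units; beyond the scatter), which shows that the large earlier step is not unique to methyl. Nothing on hand explains why these two groups read alike.

The compounds shown leave open how methoxy, an amine or a carboxylic acid on this carbon would read. They also leave open whether a plain hydrogen there would match methyl and trifluoromethyl.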